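The source may report more compounds than this note shows. Statements on the series, on what has been measured and on what is new or still open speak of the compounds shown alone.

The compounds measured so far:
compound 1 `CC(C)(C)C(=O)NCCCCN1CCN(c2ccc(Cl)cc2)CC1` gives 12.6 nM in an assay on HEK293 cells for binding affinity to D(4) dopamine receptor (Homo sapiens), read by radioligand binding; a lower number here means a stronger inhibitor, a higher number a weaker inhibitor;
compound 2 `CC(C)(C)C(=O)NCCCN1CCN(c2ccc(Cl)cc2)CC1` gives 200 nM in this assay;
compound 3 `CC(C)(C)C(=O)NCCCCCN1CCN(c2ccc(Cl)cc2)CC1` gives 126 nM in this assay.

Among these three numbers compound 3 stands second highest. Its nearest neighbour is compound 2, whose number lies within the scatter of it, so no order between them can be read. The widest gap in the set is a 10-fold higher number from compound 1 to compound 3 (1.00 log units; beyond the scatter), which places compound 3 well above the lowest number.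

Compound 4 `CC(=O)NCCCCN1CCN(c2ccc(Cl)cc2)CC1` has not yet been measured. It differs from compound 3 in one place: acetamido in place of (((tert-butyl)carbonyl)amino)methyl on a saturated chain carbon, four bonds along the chain from an amine nitrogen in a ring. Two things change at once. Among the compounds with values here, the chain returns to the length found in compound 1, which reverses the lengthening recorded by a 10-fold higher number from compound 1 to compound 3 (1.00 log units; beyond the scatter), a modest step; and the tert-butyl of the amide gives way to a methyl, for which no measured pair exists. The step of a 16-fold higher number from compound 1 to compound 2 (1.20 log units; beyond the scatter) shows that the shorter chain of compound 2 carries a large penalty, but compound 4 does not go that far. The chain step alone would argue for a clearly lower number in this assay for compound 4; the amide change adds uncertainty in either direction. Compound 4 is therefore expected to give 30 nM in this assay, within 8 nM to 120 nM, an expected step of a 4.2-fold lower number from compound 3 to compound 4 (0.62 log units; beyond the scatter).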

Compound 4, inhibition constant: 1260 nM
Compound 4: middle estimate off by 42-fold (1.62 log units), on the low side; the measured number lies above the stated range.
By their numbers in this assay, from the lowest: compound 1; then compounds 3 and 2 (each within the scatter of the next); then compound 4.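

Within the data shown here, with the chain held at the length found in compound 1, methyl in place of tert-butyl on a carbonyl carbon gives a 100-fold higher number from compound 1 to compound 4 (2.00 log units; beyond the scatter) in this assay, which shows that the group on the amide carbonyl, untouched by the earlier pairs, has a large effect on this number. The low number of compound 1 therefore does not follow from chain length alone: compound 4 shares that chain, yet the comparison with the longer chain gives a 10-fold higher number from compound 3 to compound 4 (1.00 log units; beyond the scatter) and the comparison with the shorter chain gives a 6.3-fold higher number from compound 2 to compound 4 (0.80 log units; beyond the scatter), so the methyl amide sits above both tert-butyl amides that have a less favourable chain. Nothing at hand gives a reason for this loss.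

The compounds shown leave open where an ethyl, isopropyl or cyclohexyl group on the carbonyl would stand relative to methyl and tert-butyl, and so whether the number follows the size of this group at all. They also leave open whether the preference for the chain of compound 1 would persist with a methyl amide, or with a benzamide in its place.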